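This account rests on a few compounds, and the source may have more. Where it says the series, first, only, none or still open, it means among the compounds named here.

Measured compounds:
- compound 1 `O=C(c1ccc2c(c1)OCCO2)N1N=C(c2ccccc2)CC1c1cccc(F)c1`: 1840 nM
- compound 2 `O=C(C1COc2ccccc2O1)N1N=C(c2ccccc2)CC1c1ccc(F)cc1`: 3270 nM
- compound 3 `O=C(C1COc2ccccc2O1)N1N=C(c2ccc(Br)cc2)CC1c1ccc(F)cc1`: 5630 nM

All values come from a functional assay on WM 266-4 cells (Homo sapiens) for inhibition, read by MTT assay, with a stated time of 24 h; on this read-out higher numbers stand for weaker inhibition of growth and lower numbers for stronger inhibition of growth. Compound 1 and compound 2 share the same atoms joined differently; the difference between the two cores is not broken down here. Compound 2 and compound 3 differ by bromo in place of hydrogen on an aromatic carbon, which gave a 1.7-fold higher number from compound 2 to compound 3 (0.24 log units; within the scatter). Compound 4 `O=C(c1ccc2c(c1)OCCO2)N1N=C(c2ccc(Br)cc2)CC1c1cccc(F)c1` is not yet measured; it differs from compound 1 by bromo in place of hydrogen on an aromatic carbon, the same change at the same kind of place, here on the core of compound 1. For the measured compounds named here, the expected step is a 1.7-fold higher number from compound 1 to compound 4 (0.23 log units; within the scatter), because the only earlier instance of this change is a 1.7-fold higher number from compound 2 to compound 3 (0.24 log units; within the scatter) and the estimate simply carries that step across. For compound 4 the estimated value is 3100 nM, with a likely range of 1500 nM to 6500 nM.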

Compound 4, concentration for 50% growth inhibition: 810 nM
Compound 4: middle estimate off by 3.8-fold (0.58 log units), on the high side; the measured number lies below the stated range.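

Bromo in place of hydrogen does not carry over as a fixed step between these two cores in this assay: the same change on two cores in this assay, a 1.7-fold higher number (0.24 log units; within the scatter) from compound 2 to compound 3 and a 2.3-fold lower number (0.36 log units; beyond the scatter) from compound 1 to compound 4, 3.9-fold (0.59 log units) apart, beyond the scatter of two such steps

The new pair shows phenyl to 4-bromophenyl giving a 2.3-fold lower number from compound 1 to compound 4 (0.36 log units; beyond the scatter), so a step taken from one core is a poor guide to the other here. What is not shown is which part of the difference between the two cores goes with this gap, and one pair per core gives no rule for any further core.

Open, from the compounds shown here alone, is how other groups on the same aromatic carbon, such as an amine, a carboxylic acid or a methoxy group, behave on each core. Also open, going by these compounds, is whether the lower number seen with bromo on the core of compound 1 extends to any of them.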